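Extending the Ketone of a Glutamate Receptor Modulator

The compounds below may be only part of what the source reports. "The series", "measured", "known", "first", "only" and "open" are said of these compounds alone.

Compound 1 `CC(=O)c1ccc(OCCCCOc2cccc(C(=O)O)c2C)c(C)c1O` carries an acetyl group on its phenol ring and is the better of the two compounds with a number in an assay on HEK293 cells for positive allosteric modulation of metabotropic glutamate receptor 2 (Rattus norvegicus), read by thallium flux, with a stated time of 2.5 min; a lower number here means that less compound is needed, a higher number that more compound is needed for the effect: compound 1 gives 200 nM, while compound 3 `Cc1ccc(C(=O)O)cc1OCCCCOc1ccc(C(=O)CC2CCCC2)c(O)c1C` gives 1290 nM, a gap well beyond the scatter. Compound 2 `Cc1c(OCCCCOc2ccc(C(=O)O)cc2)ccc(C(=O)CC(C)C)c1C` has no result in this assay: for compound 2 the entry reads "not determined" (no result reported). Compound 4 `CCCC(=O)c1ccc(OCCCCOc2cccc(C(=O)O)c2C)c(C)c1O` differs from compound 1 in a single place: ethyl in place of hydrogen on a saturated chain carbon bound to a carbonyl carbon. Among the compounds with values here, no measured pair in this set isolates that change, and compound 3 differs from compound 1 in more than one place, so its weaker value cannot be tied to its ketone alone. The author expects the step of a 1.5-fold higher number from compound 1 to compound 4 (0.18 log units; within the scatter) to be small, within or only slightly beyond the scatter. Compound 4 is therefore estimated at 300 nM, with a likely range from 100 nM to 900 nM.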

Compound 4, half-maximal effective concentration: 52 nM
Estimate against measurement, compound 4: 5.8-fold (0.76 log units) above; measured number below the stated range.
By their numbers in this assay, from the lowest: compound 4; then compound 1; then compound 3.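

Within the data shown here, replacing hydrogen with ethyl on the saturated chain carbon bound to the carbonyl carbon gives a 3.8-fold lower number from compound 1 to compound 4 (0.59 log units; beyond the scatter) in this assay and offers the first comparison that isolates a change at this ketone. It shows that this position accepts the longer propylcarbonyl group in place of acetyl with a modest improvement, not a loss. Nothing measured here explains the step. From the compounds shown here alone, whether a longer chain on this ketone would extend the step remains open, as does the effect of an amine at the chain end. Compound 3 cannot settle this, as it differs from compound 1 in more than one place.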